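Swapping Methyl for Fluoro on the Aryl Ring

A few compounds are considered here, and "the series" means these few. Any claim that something is new, unique, unknown or untested is made for them only; others in the source may bear on it.

In a functional assay on M14 cells (Homo sapiens) for cytotoxicity (on this read-out lower numbers stand for stronger inhibition of growth and higher numbers for weaker inhibition of growth), compound 2 `CSc1ccc(C2=C(c3ccc(C)cc3)C(=O)N3CCCC3C2)cc1` gives 6000 nM, the higher of the two numbers, while compound 1 `CSc1ccc(C2=C(c3ccc(C)c(C)c3)C(=O)N3CCCC3C2)cc1` gives 800 nM. Compound 3 `CSc1ccc(C2=C(c3ccc(F)cc3)C(=O)N3CCCC3C2)cc1` follows from compound 2 by fluoro in place of methyl on an aromatic carbon, para to a large group. Within the data shown here, the one measured step that bears on this, a 7.5-fold higher number from compound 1 to compound 2 (0.88 log units; beyond the scatter), is hydrogen in place of methyl, and no measured step introduces fluoro. A small step toward a higher number is therefore expected in this assay, possibly within the scatter. The expected value for compound 3 is 8000 nM, with an estimated range of 2500 nM to 25000 nM.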

Compound 3, concentration for 50% growth inhibition: 600 nM
For compound 3 the middle estimate is 13-fold (1.12 log units) above the measured one; measured number below the stated range.
By their numbers in this assay, from the lowest: compounds 3 and 1 (each within the scatter of the next); then compound 2.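

In this assay, the change from 4-methylphenyl to 4-fluorophenyl gives a 10-fold lower number from compound 2 to compound 3 (1.00 log units; beyond the scatter), so a single fluoro para to a large group moves the number without the second methyl of compound 1. The remaining comparison, a 1.3-fold lower number from compound 1 to compound 3 (0.12 log units; within the scatter), places 4-fluorophenyl level with 3,4-dimethylphenyl. Nothing at hand explains the effect of the fluoro.

Open, on these data alone, is whether chloro, methoxy or trifluoromethyl in this place would behave like fluoro. Also open, as far as these compounds go, is whether a second fluoro or a methyl added to the 4-fluorophenyl ring would lower the number further.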